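The source may hold more compounds than are shown below. What is called first, only, known or untested is meant among the compounds shown, and "the series" means these compounds.

Compound 2 `CCOC(=O)C1=C(C)NC(=O)NC1c1cn(C(=O)CNc2ccc([N+](=O)[O-])cc2C)c2ccccc12` gives the lowest of the three numbers in a physicochemical assay for lipophilicity (on this read-out higher numbers stand for higher lipophilicity and lower numbers for lower lipophilicity), namely 1.94; compound 3 `CCOC(=O)C1=C(C)NC(=S)NC1c1cn(C(=O)CNc2ccccc2[N+](=O)[O-])c2ccccc12` gives 2.88 and compound 1 `CCOC(=O)C1=C(C)NC(=S)NC1c1cn(C(=O)CNc2ccccc2)c2ccccc12` gives 2.92, both beyond the scatter above it. Compound 4 `CCOC(=O)C1=C(C)NC(=O)NC1c1cn(C(=O)CNc2cccc([N+](=O)[O-])c2)c2ccccc12` differs from compound 2 by 3-nitrophenyl in place of 2-methyl-4-nitrophenyl on an amine nitrogen. Within the data shown here, the only measured step, a number 0.04 log units lower from compound 1 to compound 3 (within the scatter), shows that a nitro group added to an aromatic carbon left this assay unchanged; no measured step shows the loss of a methyl group from the aromatic ring. Given that a number 0.04 log units lower from compound 1 to compound 3 (within the scatter) lay within the scatter, the step from compound 2 to compound 4 is expected to be small and downward, a number 0.39 log units lower from compound 2 to compound 4 (beyond the scatter). Compound 4 is therefore estimated at 1.55, within the range 1.15 to 1.95.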

Compound 4, partition coefficient: 1.48
The estimate for compound 4 lay 0.07 log units above the measured number, within the range that was stated.
By their numbers in this assay, from the lowest: compound 4; then compound 2; then compounds 3 and 1 (each within the scatter of the next).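

Replacing 2-methyl-4-nitrophenyl with 3-nitrophenyl on this amine nitrogen gives a number 0.46 log units lower from compound 2 to compound 4 (beyond the scatter) in this assay. Among these compounds, the earlier nitro step, a number 0.04 log units lower from compound 1 to compound 3 (within the scatter), did not show such a shift, so this is the first sign that the aryl group at this position can move the read-out. Nothing available explains the step.

The exchange alters the methyl and the nitro placement together, leaving their shares unseparated. Going by these compounds, how an amine or a methoxy group on this phenyl ring would read stays open, as does whether this exchange would behave alike on the core of compound 1.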